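The source may report more compounds than this note shows. Statements on the series, on what has been measured and on what is new or still open speak of the compounds shown alone.

Measured compounds in an assay on SH-EP1 cells for agonist activity at Neuronal acetylcholine receptor; alpha4/beta2 (Homo sapiens), read by FLIPR and calcium flux; on this read-out higher numbers stand for an effect only at larger amounts of compound and lower numbers for an effect already at smaller amounts:
compound 1 `CC(=O)N1CC2CC(C1)N2`, 9700 nM
compound 2 `CC(C)C(=O)N1CC2CC(C1)N2`, 20000 nM
compound 3 `O=C(CC1C=CCC1)N1CC2CC(C1)N2`, 37000 nM

Compound 2 stands second highest of the three; its gap to compound 3 lies within the scatter, while its gap to compound 1 lies beyond it. Compound 4 `O=C([C@@H]1C[C@@H]1F)N1CC2CC(C1)N2` is not yet measured. The change from compound 2 is 2-fluorocyclopropyl in place of isopropyl on a carbonyl carbon. Among the compounds with values here, two measured steps bear on it, both enlarging the group on the carbonyl carbon: a 2.1-fold higher number from compound 1 to compound 2 (0.31 log units; beyond the scatter) and a 3.8-fold higher number from compound 1 to compound 3 (0.58 log units; beyond the scatter). Both were modest and in the same direction. Compound 4 keeps a group of similar size to isopropyl, so the expected step of no change at the digits printed from compound 2 to compound 4 (within the scatter) is none beyond the scatter. Compound 4 is therefore estimated at 20000 nM, with a range of 8000 nM to 50000 nM.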

Compound 4, half-maximal effective concentration: 370 nM
For compound 4 the middle estimate is 54-fold (1.73 log units) above the measured one; measured number below the stated range.
By their numbers in this assay, from the lowest: compound 4; then compound 1; then compounds 2 and 3 (each within the scatter of the next).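

In this assay, 2-fluorocyclopropyl on a carbonyl carbon gives a 54-fold lower number from compound 2 to compound 4 (1.73 log units; beyond the scatter) and a 26-fold lower number from compound 1 to compound 4 (1.42 log units; beyond the scatter). This position can therefore lower the number strongly, whereas the earlier changes there only raised it, so compound 4 goes against the earlier trend and the size of the group alone does not order the series. Nothing at hand explains why this change has so large a step. The compounds shown leave open whether the gain needs the fluorine, which plain cyclopropyl would test. They also leave open whether it depends on the stereocentres, which the other stereoisomers of 2-fluorocyclopropyl would test.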